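This account rests on a few compounds, and the source may have more. Where it says the series, first, only, none or still open, it means among the compounds named here.

Measured so far in a functional assay on KBVIN cells (Homo sapiens) for cytotoxicity, read by sulforhodamine B assay; on this read-out lower numbers stand for stronger inhibition of growth and higher numbers for weaker inhibition of growth:
- compound 1 `COc1ccc2c(c1)C(=O)CCN2c1nc(C)nc2ccccc12`: 21 nM
- compound 2 `COc1ccc2c(c1)CCN2c1nc(Cl)nc2ccccc12`: 197 nM

Compound 2 holds the higher of the two numbers at 197 nM. Compound 1 lies lower at 21 nM, a gap beyond the scatter. The two compounds differ in more than one place, so this gap is not a clean measure of any single change.

Next in the series is compound 3 `COc1ccc2c(c1)CCN2c1nc(C)nc2ccccc12`, which keeps the core of compound 2. Its change is methyl in place of chloro on an aromatic carbon, between two ring nitrogen atoms (methyl in place of chloro on an aromatic carbon). Within the data shown here, no measured pair isolates this swap. Among the measured compounds shown here, the only guide is compound 1, which carries methyl at this place and reads 21 nM, though its core differs from that of compound 3. A moderate move to a lower number in this assay is therefore expected, with a result within the scatter of compound 2 still possible. The expected size is a 3.3-fold lower number from compound 2 to compound 3 (0.52 log units; beyond the scatter). Compound 3 is estimated at 60 nM, with an expected range of 15 nM to 240 nM.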

Compound 3, concentration for 50% growth inhibition: 216 nM
Compound 3: the middle estimate sits 3.6-fold (0.56 log units) below what was measured; the measured number falls inside the stated range.
By their numbers in this assay, from the lowest: compound 1; then compounds 2 and 3 (each within the scatter of the next).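

Methyl in place of chloro on the aromatic carbon between two ring nitrogen atoms gives a 1.1-fold higher number from compound 2 to compound 3 (0.04 log units; within the scatter) in this assay, so on this shared core the two groups cannot be told apart at this place. Among these compounds, this is the first pair that isolates the change, and it gives no sign that methyl at this carbon lowers the number on its own, even though compound 1 also carries methyl there on a different core. No data bearing on why the swap leaves the read-out within the scatter are at hand.

On these data alone, both groups compared here count one heavy atom, so whether an amine or a longer chain such as propyl at this carbon would move the number remains open. Among the compounds shown here, also open is whether the same swap on the core of compound 1 would again stay within the scatter, and no single-change pair yet connects that core to compound 2 or compound 3.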